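The source may hold more compounds than are shown below. What is called first, only, known or untested is meant among the compounds shown, and "the series" means these compounds.

Compounds measured so far in an ADME assay on cells (Fibroblast, Gallus gallus) for cytotoxicity, read by CCK-8 assay, with a stated time of 48 h; on this read-out lower numbers stand for higher toxicity in this test and higher numbers for lower toxicity in this test:

Compound 1, `CCc1ccc(CN[C@H]2CC(C(=O)O)=C[C@@H](OC(CC)CC)[C@@H]2NC(C)=O)cc1`: > 200000 nM — a limit of the assay, not a number.
Compound 2, `CCC(CC)O[C@@H]1C=C(C(=O)O)C[C@H](NCc2ccc(OC(C)C)cc2)[C@H]1NC(C)=O`: > 200000 nM — likewise a limit.
Compound 3, `CCC(CC)O[C@@H]1C=C(C(=O)O)C[C@H](NCc2ccc(SC3CCCCC3)cc2)[C@H]1NC(C)=O`: > 200000 nM — likewise a limit.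

All three compounds share one core and differ only in the group carried on the aromatic carbon of the benzyl ring. For compound 2 the value in this assay is only a limit, and the two other values shown are limits as well, so compound 2 cannot be ranked against compound 1 or compound 3. The measured steps between them are accordingly unreadable: a step that the two limits leave unreadable from compound 1 to compound 2, a step that the two limits leave unreadable from compound 1 to compound 3 and a step that the two limits leave unreadable from compound 2 to compound 3 all give no size, because the limit of > 200000 nM in this assay, at which 3 of the 3 values shown sit, is where every value sits.

Compound 4, `CCC(CC)O[C@@H]1C=C(C(=O)O)C[C@H](NCc2ccc(-c3cc4ccccc4s3)cc2)[C@H]1NC(C)=O`, is the next member, and it carries the change (1-benzothiophen-2-yl in place of isopropoxy on an aromatic carbon). Ethyl, isopropoxy and cyclohexylsulfanyl on that carbon have all left the read-out at the limit, so no step with a readable size bears on this change, and nothing in the data argues for toxicity appearing with the new group. The expected step from compound 2 to compound 4 is therefore a step that the limit leaves unreadable from compound 2 to compound 4, that is none beyond the scatter. Compound 4 is estimated at 250000 nM in this assay, within 120000 nM to 500000 nM, and most likely again reported only as a limit.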

Compound 4, half-maximal cytotoxic concentration: > 200000 nM
Compound 4 was reported as a limit (the forecaster's own chance of this, stated with the estimate: 75%); the middle value does not contradict the limit.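

Compound 4 gives > 200000 nM in this assay, which is a limit and not a number. No step between compound 4 and compound 1, compound 2 or compound 3 can be read, because all four compounds share the same limit: the limit of > 200000 nM in this assay, at which 4 of the 4 values shown sit.

The compounds shown leave open whether any group on that aromatic carbon would bring a readable value in this assay.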